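Iodo in place of thiophen-2-yl: an expected value

A few compounds are considered here, and "the series" means these few. Any claim that something is new, unique, unknown or untested is made for them only; others in the source may bear on it.

Compound 1 `COc1ncnc2c1c(-c1cccs1)cn2[C@@H]1O[C@H](CO)[C@@H](O)[C@H]1O` — 12100 nM in a functional assay on CEM-DNR-bulk cells (Homo sapiens), read by MTT assay, with a stated time of 72 h; a lower number here means a stronger inhibitor, a higher number a weaker inhibitor
Compound 2 `CSc1ncnc2c1c(-c1cccs1)cn2[C@@H]1O[C@H](CO)[C@@H](O)[C@H]1O` — > 20000 nM, a limit of this assay
Compound 3 `CN(C)c1ncnc2c1c(-c1cccs1)cn2[C@@H]1O[C@H](CO)[C@@H](O)[C@H]1O` — > 20000 nM, a limit of this assay

In this assay compound 1 gives 12100 nM and holds the only number shown. For compound 2 the value > 20000 nM is a limit of the assay, not a number. For compound 3 the value > 20000 nM is likewise a limit. The two steps of an at least 1.6-fold higher number from compound 1 to compound 2 (0.21 log units; that floor lies within the scatter) and an at least 1.6-fold higher number from compound 1 to compound 3 (0.21 log units; that floor lies within the scatter) both end at the limit of > 20000 nM in this assay, at which 2 of the 3 values shown sit, and both vary the methoxy while the thiophen-2-yl stays. Compound 4 `COc1ncnc2c1c(I)cn2[C@@H]1O[C@H](CO)[C@@H](O)[C@H]1O` differs from compound 1 by iodo in place of thiophen-2-yl on an aromatic carbon. No measured step touches this position, so no direction can be read from the shown steps, and the expected step of a 1.2-fold lower number from compound 1 to compound 4 (0.08 log units; within the scatter) is kept small. Compound 4 is estimated at 10000 nM, between 1500 nM and 20000 nM.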

Compound 4, half-maximal inhibitory concentration: > 20000 nM
Compound 4 was reported as a limit; the forecaster's own chance of this, stated with the estimate: 35%; at least 2.0-fold (0.30 log units) between middle value and limit.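

Among these compounds, this is the first measured change at this position, the aromatic carbon two ring bonds from the ring nitrogen, and in this assay iodo in place of thiophen-2-yl gives an at least 1.6-fold higher number from compound 1 to compound 4 (0.21 log units; that floor lies within the scatter). The value for compound 4 is a limit and not a number, so the change yields no lower number, and the true size of the step cannot be read. Changes at this position and at the methoxy now end alike, leaving compound 1 as the only compound with a number: the limit of > 20000 nM in this assay, at which 3 of the 4 values shown sit.

The compounds shown leave open whether a phenyl ring, a furan-2-yl ring or an amine at this position would give a number lower than that of compound 1.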